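This account rests on a few compounds, and the source may have more. Where it says the series, first, only, none or still open, it means among the compounds named here.

Of the compounds shown here, two have been measured so far. Compound 1 `CC(C)N1CCN(c2ccc3c(c2)oc(=O)n3C(=O)NCCCCc2ccccc2)CC1` gives 211 nM in an assay on HEK293 cells for inhibition of acid ceramidase (Homo sapiens), read by fluorescence, with stated times of 10 min and 3 h; a lower number here means a stronger inhibitor, a higher number a weaker inhibitor. Compound 2 `CN1CCC(c2ccc3c(c2)oc(=O)n3C(=O)NCCCCc2ccc(F)cc2)CC1` gives 94 nM in this assay. On these two numbers compound 1 stands at the higher end, with compound 2 the lower of the pair by a margin beyond the usual scatter.

The next compound to be examined, compound 3 `CCN1CCC(c2ccc3c(c2)oc(=O)n3C(=O)NCCCCc2ccccc2)CC1`, keeps the shared core and the tail of compound 1 and differs from it in one place: 1-ethylpiperidin-4-yl in place of 4-isopropylpiperazin-1-yl on an aromatic carbon. No such exchange has yet been measured, so its size cannot be read directly from a completed step.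

What can be said rests on compound 2, which carries a close relative of the incoming group and gives 94 nM. On that basis a modest move toward a lower number is expected in this assay, one that is estimated as a 1.8-fold lower number from compound 1 to compound 3 (0.25 log units; within the scatter). Compound 3 is therefore expected to give about 120 nM, with a plausible range from 50 nM to 300 nM.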

Compound 3, half-maximal inhibitory concentration: 92 nM
For compound 3 the middle estimate is 1.3-fold (0.12 log units) above the measured one, and the stated range covers the measured number.
By their numbers in this assay, from the lowest: compounds 3 and 2 (each within the scatter of the next); then compound 1.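

In this assay, this position now has a completed step of its own, a 2.3-fold lower number from compound 1 to compound 3 (0.36 log units; beyond the scatter), with the shared core and the tail held unchanged, so the difference belongs to the exchange of 4-isopropylpiperazin-1-yl for 1-ethylpiperidin-4-yl on this aromatic carbon. For the compounds shown here, that exchange alters two features at once: the six-membered ring goes from two hetero atoms to one, and the alkyl group on the ring nitrogen goes from isopropyl to ethyl, so the single step does not show how much of the difference belongs to either feature. No measurement is at hand that explains the size of this step.

The compounds shown leave the two features unseparated, since a 4-ethylpiperazin-1-yl or a 1-isopropylpiperidin-4-yl group at this position would be needed to divide the step. They also leave open how far the position tolerates other groups, such as a piperidin-4-yl ring with a hydrogen on its nitrogen or a morpholine, and what a fluorine on the phenyl ring of the tail contributes when the 1-ethylpiperidin-4-yl group is kept.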